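A Smaller Ring on a Tightly Bound Compound

The source may report more compounds than this note shows. Statements on the series, on what has been measured and on what is new or still open speak of the compounds shown alone.

Measured in an ADME assay on a cell-free system (plasma, Rattus norvegicus); on this read-out higher numbers stand for a larger free fraction and lower numbers for a smaller free fraction:
- compound 1 `CC(=O)Nc1cc(-c2ccc(N(C)C(=O)c3c(F)cccc3Cl)c(N3CC4CC4C3)c2)n(C2CCCC2)n1`: < 0.0005
- compound 2 `CC(=O)Nc1cc(-c2cnc(N(C)C(=O)c3c(F)cccc3Cl)c(N3CC4CC4C3)c2)n(C(C)C)n1`: 0.022

Going by these compounds, the entry for compound 1 is a limit of the assay and not a number, so its true free fraction remains unknown. This is the position described by the limit of < 0.0005 in this assay, at which 1 of the 2 values shown sits. Compound 2, in contrast, gives a real number of 0.022.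

Compound 3 `CC(=O)Nc1cc(-c2ccc(N(C)C(=O)c3c(F)cccc3Cl)c(N3CC4CC4C3)c2)n(C2CCC2)n1` keeps the core of compound 1 and carries cyclobutyl in place of cyclopentyl on an aromatic nitrogen. Among the compounds with values here, no pair of measured compounds isolates this swap, so the forecast has no direct precedent and rests only on how modest the structural change is. In this assay, a small step towards a larger free fraction is expected, and it may not clear the usual scatter. The estimated step of an at least 1.6-fold higher number from compound 1 to compound 3 (0.20 log units; that floor lies within the scatter) is therefore only a rough expectation. The assay could also report just a limit again. For compound 3, the expected value is 0.0008, with an estimated range of 0.0003 to 0.003.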

Compound 3, unbound fraction: 0.0004
Compound 3: middle estimate off by 2.0-fold (0.30 log units), on the high side; the range from low to high includes it.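

No step can be read between compound 1 and compound 3, since the comparison rests on a limit and not a number: the limit of < 0.0005 in this assay, at which 1 of the 3 values shown sits. The compounds shown leave open the true free fraction of compound 1, and so whether cyclobutyl in place of cyclopentyl changes the result in this assay at all.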